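Swapping hydroxyl position on a trisubstituted pyridine core

The source may hold more compounds than are shown below. What is called first, only, known or untested is meant among the compounds shown, and "the series" means these compounds.

Measured so far, in a functional assay on DU-145 cells (Homo sapiens) for cytotoxicity, read by CCK-8 assay; a higher number here means a weaker inhibitor, a lower number a stronger inhibitor:
compound 1 `Oc1cccc(-c2cc(-c3cccs3)cc(-c3cccc(O)c3)n2)c1` gives 1630 nM;
compound 2 `Oc1ccc(-c2cc(-c3cccs3)cc(-c3cccc(O)c3)n2)cc1` gives 1890 nM;
compound 3 `Oc1ccc(-c2cc(-c3ccccn3)cc(-c3cccc(O)c3)n2)cc1` gives 1980 nM.

The change 4-hydroxyphenyl in place of 3-hydroxyphenyl on an aromatic carbon moved the number by a 1.2-fold higher number from compound 1 to compound 2 (0.06 log units; within the scatter). The step of a 1.0-fold higher number from compound 2 to compound 3 (0.02 log units; within the scatter) is likewise within the scatter. The difference between the cores of compound 1 and compound 3 is not broken down here.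

Compound 4 `Oc1ccc(-c2cc(-c3ccccn3)cc(-c3ccc(O)cc3)n2)cc1` carries the same kind of change as before: 4-hydroxyphenyl in place of 3-hydroxyphenyl on an aromatic carbon. The surroundings differ, since in compound 1 the place is meta to a 3-hydroxyphenyl group and meta to a thiophen-2-yl group, while in compound 3 it is meta to a 4-hydroxyphenyl group and meta to a pyridin-2-yl group. Because a 1.2-fold higher number from compound 1 to compound 2 (0.06 log units; within the scatter) stayed within the scatter, the expected step is a 1.1-fold higher number from compound 3 to compound 4 (0.03 log units; within the scatter). Compound 4 is thus estimated at 2100 nM, likely between 1200 nM and 3800 nM.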

Compound 4, half-maximal inhibitory concentration: > 50000 nM
Compound 4: no number, only a limit (the forecaster's own chance of this, stated with the estimate: 5%); at least 23-fold (1.37 log units) between middle value and limit.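

In this assay compound 4 gives > 50000 nM, which is a limit of the assay and not a number. The same swap of groups gives an at least 25-fold higher number from compound 3 to compound 4 (1.40 log units; beyond the scatter), so it does not carry over unchanged from the core of compound 1 to the core of compound 3: the same change on two cores in this assay, a 1.2-fold higher number (0.06 log units; within the scatter) from compound 1 to compound 2 and an at least 25-fold higher number (1.40 log units; beyond the scatter) from compound 3 to compound 4, at least 21-fold (1.33 log units) apart, beyond the scatter of two such steps This does not show which difference between those cores matters, the pyridin-2-yl in place of thiophen-2-yl or the second 4-hydroxyphenyl group, and the limit hides the true size of the step.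

The compounds shown leave open whether the swap behaves the same way with thiophen-2-yl on the core, and what an amine or a carboxylic acid in place of the hydroxyl would do.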